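Ester variation on a hydroxy-amide series: ethyl to benzyl

A few compounds are considered here, and "the series" means these few. Any claim that something is new, unique, unknown or untested is made for them only; others in the source may bear on it.

Three close analogues have been measured in an ADME assay on HEK293 cells (Homo sapiens) for inhibition, read by CellTiter-Glo, with a stated time of 96 h, tested at 100 uM; a higher number here means more inhibition at the concentration tested (going by the name of the read-out), a lower number less inhibition. Compound 1 `CCOC(=O)/C=C\NC(=O)[C@H](O)C(C)(C)CO` gives -6%. Compound 2 `CC(C)(C)OC(=O)/C=C/NC(=O)[C@H](O)C(C)(C)CO` gives -1%, and compound 3 `CC(C)(C)OC(=O)/C=C\NC(=O)[C@@H](O)C(C)(C)CO` gives -11%. All three numbers sit within the usual scatter of one another, so compound 1 cannot be set apart from either neighbour on these data. For the measured compounds named here, the only single-point step measured so far is a number 10 percentage points lower from compound 2 to compound 3 (within the scatter), which rests on the fact that compounds 2 and 3 differ only in the configuration as drawn and says nothing about the ester group.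

Compound 4 `CC(C)(CO)[C@@H](O)C(=O)N/C=C\C(=O)OCc1ccccc1` has not yet been measured. It differs from compound 1 in that (phenyl in place of methyl on a saturated chain carbon bound to an oxygen next to a carbonyl group); cut one bond further out, the change reads ethyl to benzyl. Going by the values given here, no measured step touches this position, so there is no measured basis for a shift in either direction, and the numbers seen so far all lie around zero. The expectation for compound 4 in this assay is therefore a step of about a number 1 percentage points higher from compound 1 to compound 4 (within the scatter), that is, nothing beyond the scatter. Compound 4 is estimated at -5%, with a range from -20% to 10%.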

Compound 4, a percentage reported as inhibition, at one concentration (the size of the read-out at that concentration, not a potency): 7%
For compound 4 the middle estimate is 12 percentage points below the measured one, within the range that was stated.
By their numbers in this assay, from the lowest: compounds 3, 1, 2 and 4 (each within the scatter of the next, the first and the last beyond it).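

Ethyl to benzyl at this position gives a number 13 percentage points higher from compound 1 to compound 4 (beyond the scatter) in this assay, the first step in the series to be printed as lying outside the scatter, so this position is not silent in a way the earlier compounds could not show. The step remains modest and rests on a single pair of compounds, with phenyl in place of methyl on a saturated chain carbon bound to an oxygen next to a carbonyl group, and one six-membered aromatic ring of carbon only as the added feature. Nothing in the evidence at hand bears on what lies behind this step.

From the compounds shown here alone, whether a longer chain carrying the phenyl, or a free carboxylic acid in place of the ester, would sit with compound 4 or with compound 1 remains open. Also open, going by these compounds, is whether the same change would give a similar step on the double-bond configuration drawn in compound 2.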